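The source may report more compounds than this note shows. Statements on the series, on what has been measured and on what is new or still open speak of the compounds shown alone.

Three compounds that share one core and differ only in the group on a carbonyl carbon have been run through an ADME assay on Huh-7 cells (Homo sapiens) for cytotoxicity, read by MTT assay, with a stated time of 72 h; a lower number here means that less compound is tolerated, a higher number that more compound is tolerated. Compound 1 `NC(=O)c1sc2nc(-c3ccccc3)cc(C(F)(F)F)c2c1N` carries an amino group there, and in this assay compound 1 gives only a limit, > 20000 nM. Compound 2 `CCOC(=O)c1sc2nc(-c3ccccc3)cc(C(F)(F)F)c2c1N` carries an ethoxy group, and in this assay compound 2 gives only a limit, > 20000 nM. Compound 3 `CN(C)C(=O)c1sc2nc(-c3ccccc3)cc(C(F)(F)F)c2c1N` carries a dimethylamino group, and in this assay compound 3 gives only a limit, > 20000 nM. Compound 3 thus stands with the others at the limit of > 20000 nM in this assay, at which 3 of the 3 values shown sit. The steps a step that the two limits leave unreadable from compound 1 to compound 2, a step that the two limits leave unreadable from compound 1 to compound 3 and a step that the two limits leave unreadable from compound 2 to compound 3 cannot be sized. Compound 4 `CCN(CC)C(=O)c1sc2nc(-c3ccccc3)cc(C(F)(F)F)c2c1N` differs from compound 3 by diethylamino in place of dimethylamino on a carbonyl carbon. With every measured step unreadable, no change beyond the scatter is expected, so a step that the limit leaves unreadable from compound 3 to compound 4 is the expected step. Compound 4 is expected to give 25000 nM, between 10000 nM and 60000 nM.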

Compound 4, half-maximal cytotoxic concentration: > 100000 nM
Compound 4: only a limit was reported (the forecaster's own chance of this, stated with the estimate: 80%); at least 4.0-fold (0.60 log units) between middle value and limit.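

Compound 4, like compound 1, compound 2 and compound 3, gives only a limit in this assay, so none of the steps to compound 4 can be read. The compounds shown leave open whether the group on the carbonyl carbon changes cytotoxicity at all.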